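This account rests on a few compounds, and the source may have more. Where it says the series, first, only, none or still open, it means among the compounds named here.

Measured compounds:
- compound 1, `COc1cccc(S(=O)(=O)c2cnc3ccc(OC)cc3c2N2CCC(C)CC2)c1`: 0%
- compound 2, `COc1ccc2ncc(S(=O)(=O)c3ccc(OC)c(OC)c3)c(N3CCC(C)CC3)c2c1`: -3%

In an assay on isolated protein for displacement of a labelled ligand from metabotropic glutamate receptor 5 (Homo sapiens), with a stated time of 60 min, tested at 1 uM (a lower number here means less inhibition, a higher number more inhibition at the concentration tested (going by the name of the read-out)), compound 1 gives 0% and compound 2 gives -3%. Among the measured compounds shown here, the one measured step, methoxy in place of hydrogen on an aromatic carbon, amounts to a number 3 percentage points lower from compound 1 to compound 2 (within the scatter). For the measured compounds named here, compound 2 thus stands at the lower of the two numbers, with compound 1 as its only neighbour, and the two are within the scatter of each other, so no order between them can be read.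

Compound 3, `COc1ccc2ncc(S(=O)(=O)c3cc(Cl)cc(Cl)c3)c(N3CCC(C)CC3)c2c1`, differs from compound 2 as follows: 3,5-dichlorophenyl in place of 3,4-dimethoxyphenyl on a sulfonyl sulfur. Going by the values given here, no measured step touches the group on the sulfonyl sulfur, so the step from compound 1 to compound 2 does not bear directly on this change, and it was itself within the scatter. The data give no ground for expecting a step beyond the scatter in this assay from this change either, since both measured compounds sit near zero.

Compound 3 is therefore estimated at 5%, within -15% to 35%. The step from compound 2 to compound 3 that this estimate means is expected to be a number 8 percentage points higher from compound 2 to compound 3 (within the scatter), which is within the scatter.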

Compound 3, a percentage reported as inhibition, at one concentration (the size of the read-out at that concentration, not a potency): 87%
The estimate for compound 3 lay 82 percentage points below the measured number; measured number outside the range, above it.
By their numbers in this assay, from the lowest: compounds 2 and 1 (each within the scatter of the next); then compound 3.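

The group on the sulfonyl sulfur proves to be a place where this assay responds strongly, which the earlier methoxy step could not show: 3,5-dichlorophenyl in place of 3,4-dimethoxyphenyl gives a number 90 percentage points higher from compound 2 to compound 3 (beyond the scatter), and 3,5-dichlorophenyl in place of 3-methoxyphenyl gives a number 87 percentage points higher from compound 1 to compound 3 (beyond the scatter). Both steps are large and beyond the scatter, so the rise appears whichever of the two methoxy-bearing groups leaves, while the difference between those two groups had stayed within the scatter. Nothing available explains why this exchange matters so much.

The compounds shown do not separate the part played by the chlorines from that of their placement on the ring, and it stays open whether a fluorine, a nitrile or a carboxylic acid in place of the chlorine would keep the read-out. They also leave open how potent compound 3 is, since a percentage at one concentration is not a potency, and whether the gain would survive if a morpholine took the place of the methylated saturated ring on the shared core.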